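The source may report more compounds than this note shows. Statements on the series, on what has been measured and on what is new or still open speak of the compounds shown alone.

Measured compounds:
compound 1 `CNC(=O)CCn1nc(-c2ccccc2)ccc1=O` gives 3.5% in a functional assay on the whole organism (stomach) for inhibition, with Rattus norvegicus as the target, at a dose of 100 mg/kg by the intraduodenal route; on this read-out higher numbers stand for more inhibition at the one dose given (going by the name of the read-out) and lower numbers for less inhibition
compound 2 `NC(=O)CCn1nc(-c2ccccc2)ccc1=O` gives -2.8% in this assay
compound 3 `N=C(S)CCCCCCn1nc(-c2ccccc2)ccc1=O` gives 33.9% in this assay

Among these three numbers compound 2 stands lowest. Its nearest neighbour is compound 1, and that step, a number 6.3 percentage points lower from compound 1 to compound 2 (within the scatter), lies within the scatter. The furthest is compound 3, reached by a number 36.7 percentage points higher from compound 2 to compound 3 (beyond the scatter), a large step. Compound 1 shows the same picture against compound 3, with a number 30.4 percentage points higher from compound 1 to compound 3 (beyond the scatter).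

Compound 4 `N=C(S)Cn1nc(-c2ccccc2)ccc1=O` has not yet been measured. Its structure differs from compound 2 in one place: a group of 3 heavy atoms (1 carbon, 1 nitrogen, 1 sulfur; no ring) in place of a group of 4 heavy atoms (2 carbon, 1 nitrogen, 1 oxygen; no ring), on a saturated chain carbon bound to an aromatic nitrogen. The group that enters is the same one carried by compound 3, but in compound 3 it sits at the end of a longer chain, so the two steps that bear on the present one, a number 36.7 percentage points higher from compound 2 to compound 3 (beyond the scatter) and a number 30.4 percentage points higher from compound 1 to compound 3 (beyond the scatter), each combine the change of group with a change of chain length. Going by the values given here, no measured pair separates the two. The data therefore give a direction, upward, but no clean size for the group change on its own.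

The step from compound 2 is estimated as a number 16.8 percentage points higher from compound 2 to compound 4 (beyond the scatter), an increase beyond the scatter but smaller than that to compound 3. Compound 4 is expected to give 14% in this assay, with a range from -8% to 36%.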

Compound 4, a percentage reported as inhibition, in the whole organism at one dose (the size of the read-out at that dose, not a potency): 5.5%
Compound 4: the middle estimate sits 8.5 percentage points above what was measured, within the range that was stated.
By their numbers in this assay, from the lowest: compounds 2, 1 and 4 (each within the scatter of the next); then compound 3.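

On the saturated chain carbon bound to an aromatic nitrogen, putting the sulfur-bearing group in place of carbamoylmethyl does not carry the result in this assay beyond the scatter, with a number 8.3 percentage points higher from compound 2 to compound 4 (within the scatter) and a number 2 percentage points higher from compound 1 to compound 4 (within the scatter) as the two steps, so compound 4 cannot be told apart from the two amides. The same end group gives compound 4 5.5% and compound 3 33.9% on its longer chain, which shows that this group alone does not bring the higher number and that among these compounds that number appears only together with the longer chain. No measurement shown explains why the two chain lengths give such different numbers.

Going by these compounds, what remains open is how the number changes along the chain, since no chain of intermediate length appears here, and whether a longer chain ending in the amide would match compound 3, which would show whether the chain is enough without the sulfur-bearing group. On these data alone, it is also open how other end groups, such as an amine or a carboxylic acid, would behave on the longer chain.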